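Swapping a Trifluoromethyl for an Amino Group

The source may hold more compounds than are shown below. What is called first, only, known or untested is meant among the compounds shown, and "the series" means these compounds.

Compound 2 `CC(C)(C)c1cc(NC(=O)Nc2ccc(Cl)cc2)n(-c2ccc(C(F)(F)F)cc2)n1` and compound 1 `CC(C)(C)c1cc(NC(=O)Nc2cc(C(F)(F)F)cc(C(F)(F)F)c2)n(-c2ccccc2)n1` share one core and were both tested in an assay on isolated protein for inhibition of STE20-like serine/threonine-protein kinase (Homo sapiens), read by thermal shift assay, tested at 10 uM; a higher number here means that the compound stabilises the target more against heat, a lower number that the compound stabilises the target less. Compound 2 gives 0.7 degrees C, while compound 1 gives 0 degrees C; the gap between these two numbers lies within the usual scatter, so neither stands apart from the other. Compound 3 `CC(C)(C)c1cc(NC(=O)Nc2ccc(Cl)cc2)n(-c2ccc(N)cc2)n1` is not yet measured. The change from compound 2 to compound 3 is amino in place of trifluoromethyl on an aromatic carbon. For the measured compounds named here, no measured pair shows this kind of change, so no size can be read off. The expected step from compound 2 to compound 3 is a number 0.20 degrees C lower from compound 2 to compound 3 (within the scatter), nothing beyond the scatter. Compound 3 is estimated at 0.5 degrees C, within -0.5 degrees C to 1.5 degrees C.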

Compound 3, shift of the target's melting temperature: 5.6 degrees C
Beside the measured number, compound 3's estimate is 5.1 degrees C below it; measured number above the stated range.
By their numbers in this assay, from the lowest: compounds 1 and 2 (each within the scatter of the next); then compound 3.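

In this assay, amino in place of trifluoromethyl on this aromatic carbon, para to a large group, gives a number 4.9 degrees C higher from compound 2 to compound 3 (beyond the scatter). For the compounds shown here, this is the first change here to move the number beyond the scatter, so the group at this position can strongly affect how much the compound stabilises the target. Nothing available explains the rise. The compounds shown leave open whether amino is special here, or whether a hydroxyl, a methylamino or an acetylamino group on the same carbon would give a similar number.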